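The source may report more compounds than this note shows. Statements on the series, on what has been measured and on what is new or still open speak of the compounds shown alone.

Compounds measured in a functional assay, read by spectrophotometry, with a stated time of 30 min; on this read-out lower numbers stand for stronger inhibition and higher numbers for weaker inhibition:

compound 1, `COc1cc(C2CC(=NOC(=O)c3ccccc3O)CC(c3ccc(O)c(OC)c3)N2C)ccc1O` — 15900 nM
compound 2, `COc1cc(C2CC(=NOC(=O)c3ccc(Br)cc3)CC(c3ccc(O)c(OC)c3)N2C)ccc1O` — 108000 nM

Among these two numbers compound 2 stands highest; its nearest neighbour is compound 1, and the step of a 6.8-fold higher number from compound 1 to compound 2 (0.83 log units; beyond the scatter) separates them, a modest step beyond the scatter. Compound 3, `COc1cc(C2CC(=NOC(=O)c3ccc(F)cc3)CC(c3ccc(O)c(OC)c3)N2C)ccc1O`, has not been measured in this assay. It differs from compound 2 by fluoro in place of bromo on an aromatic carbon, para to a large group. Among the measured compounds shown here, no measured step bears directly on this exchange: the one step on record, a 6.8-fold higher number from compound 1 to compound 2 (0.83 log units; beyond the scatter), concerns a different change in the same ring, and the two values show only that the ring's substitution matters here. With no halogen-to-halogen comparison available, compound 3 is expected to lie close to compound 2, with a 1.5-fold lower number from compound 2 to compound 3 (0.19 log units; within the scatter) as the estimated step, and its value in this assay is estimated at 70000 nM, within a range from 20000 nM to 200000 nM.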

Compound 3, half-maximal inhibitory concentration: 141000 nM
Estimate against measurement, compound 3: 2.0-fold (0.30 log units) below; measured number inside the range.
By their numbers in this assay, from the lowest: compound 1; then compounds 2 and 3 (each within the scatter of the next).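

In this assay, putting fluoro in place of bromo on the aromatic carbon para to a large group gives a 1.3-fold higher number from compound 2 to compound 3 (0.12 log units; within the scatter), so the two halogens cannot be told apart at this position. The change from 2-hydroxyphenyl to 4-fluorophenyl on the carbonyl carbon gives an 8.9-fold higher number from compound 1 to compound 3 (0.95 log units; beyond the scatter), which shows that the gap first seen with 4-bromophenyl is not confined to that one halogen. Nothing on record offers an explanation for these numbers.

On these data alone, it remains open whether an amine or a carboxylic acid in place of the halogen would move the number away from those of compound 2 and compound 3. As far as these compounds go, it is also open whether the gap to compound 1 follows the hydroxy group itself or its place on the ring, as these steps change both at once.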